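The source may report more compounds than this note shows. Statements on the series, on what has been measured and on what is new or still open speak of the compounds shown alone.

In a functional assay on L1210 cells (Mus musculus) for antiproliferative activity, read by cell counting, with a stated time of 96 h (on this read-out higher numbers stand for weaker inhibition and lower numbers for stronger inhibition), compound 1 `CC(Nc1ccccc1Oc1ccc(Cl)cc1)=C1C(=O)CC(c2ccccc2)CC1=O` gives 250 nM, compound 2 `COc1ccc(Oc2ccccc2NC(C)=C2C(=O)CC(c3ccccc3)CC2=O)cc1OC` gives 65 nM, and compound 3 `CC(Nc1ccccc1Oc1ccccc1)=C1C(=O)CC(c2ccccc2)CC1=O` gives 86 nM. Among these three numbers compound 3 stands second highest: its gap to compound 2 is within the scatter, while the gap to compound 1 lies beyond it. Going by the values given here, compound 4 `CC(Nc1ccccc1Oc1cccc(N)c1)=C1C(=O)CC(c2ccccc2)CC1=O` has not yet been measured; it differs from compound 3 by amino in place of hydrogen on an aromatic carbon, on the same phenoxy ring that the earlier steps altered. Those steps were a 2.9-fold lower number from compound 1 to compound 3 (0.46 log units; beyond the scatter), a 3.8-fold lower number from compound 1 to compound 2 (0.59 log units; beyond the scatter) and a 1.3-fold higher number from compound 2 to compound 3 (0.12 log units; within the scatter), so changes on this ring have shifted the number modestly or not at all. Among the compounds with values here, an amino group has no direct precedent here, so for compound 4 a step of about a 1.1-fold lower number from compound 3 to compound 4 (0.03 log units; within the scatter) is expected, within the scatter. Compound 4 is therefore estimated at 80 nM, with a range from 30 nM to 250 nM.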

Compound 4, half-maximal inhibitory concentration: 53 nM
Estimate against measurement, compound 4: 1.5-fold (0.18 log units) above; the measured number falls inside the stated range.
By their numbers in this assay, from the lowest: compounds 4, 2 and 3 (each within the scatter of the next); then compound 1.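

In this assay, an amino group on the phenoxy ring, meta to a large group, gives a 1.6-fold lower number from compound 3 to compound 4 (0.21 log units; within the scatter), and the change from the dimethoxy ring gives a 1.2-fold lower number from compound 2 to compound 4 (0.09 log units; within the scatter), so this new group, which brings a hydrogen-bond donor, produces no step beyond the scatter. Only the change from the chloro-bearing ring, a 4.7-fold lower number from compound 1 to compound 4 (0.67 log units; beyond the scatter), goes beyond it. No measurement here explains these results. On these data alone, whether a bulkier dimethylamino group or a carboxylic acid would fit equally well at this place remains open. So does the effect of amino on another carbon of this ring.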